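Swapping a Para Substituent on the Benzylsulfanyl Arm

The source may report more compounds than this note shows. Statements on the series, on what has been measured and on what is new or still open speak of the compounds shown alone.

Compound 1 `Cc1cc(-c2ccccc2)n(/C(N)=N/S(=O)(=O)c2cc(C)c(Cl)cc2SCc2ccc(C(F)(F)F)cc2)n1`: 16000 nM
Compound 2 `Cc1cc(S(=O)(=O)/N=C(\N)n2nccc2-c2ccccc2)c(SCc2ccc(C(F)(F)F)cc2)cc1Cl`: 25000 nM
Compound 3 `Cc1cc(S(=O)(=O)/N=C(\N)n2nccc2-c2ccccc2)c(SCc2ccccc2)cc1Cl`: 20000 nM

In a functional assay on MCF7 cells (Homo sapiens) for cytotoxicity, read by MTT assay, with a stated time of 72 h (on this read-out higher numbers stand for weaker inhibition and lower numbers for stronger inhibition), the three measured compounds give numbers that all lie within the scatter of one another, so compound 1 is not set apart from compound 2 or compound 3. The step of a 1.6-fold higher number from compound 1 to compound 2 (0.19 log units; within the scatter) and the step of a 1.3-fold lower number from compound 2 to compound 3 (0.10 log units; within the scatter) were both within the scatter. Compound 4 `Cc1cc(-c2ccccc2)n(/C(N)=N/S(=O)(=O)c2cc(C)c(Cl)cc2SCc2ccc(Cl)cc2)n1` differs from compound 1 by chloro in place of trifluoromethyl on an aromatic carbon. Within the data shown here, the step that bears on it most closely is the one from compound 2 to compound 3, where the same trifluoromethyl was removed without a change beyond the scatter. Compound 4 is therefore expected to show a step of no change at the digits printed from compound 1 to compound 4 (within the scatter) that stays within the scatter. The estimate for compound 4 is 16000 nM, with a range from 8000 nM to 32000 nM.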

Compound 4, half-maximal inhibitory concentration: 108000 nM
For compound 4 the middle estimate is 6.8-fold (0.83 log units) below the measured one, and the stated range ends below it.
By their numbers in this assay, from the lowest: compounds 1, 3 and 2 (each within the scatter of the next); then compound 4.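

In this assay, among these compounds, this position proves sensitive to the group it carries: chloro in place of trifluoromethyl gives a 6.8-fold higher number from compound 1 to compound 4 (0.83 log units; beyond the scatter) and is the only step here beyond the scatter. Removing trifluoromethyl from compound 2 to compound 3 stayed within the scatter, so a change at this place on one core does not predict a change at this place on another. Nothing given here accounts for the step. On these data alone, whether a methoxy group or an amine at this place on the core of compound 1 would fall nearer compound 1 or compound 4 remains open. So does whether chloro has the same outcome on the core of compound 2.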